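Moving One Chlorine Atom on Compound 1

This account rests on a few compounds, and the source may have more. Where it says the series, first, only, none or still open, it means among the compounds named here.

Values from a functional assay on NUGC-3 cells (Homo sapiens) for cytotoxicity, read by sulforhodamine B assay, with a stated time of 72 h (on this read-out higher numbers stand for weaker inhibition of growth and lower numbers for stronger inhibition of growth), are these
Compound 1 (`O=C(Nc1cc(C(F)(F)F)cc(C(F)(F)F)c1)C1CCc2ccccc2N1C(=O)c1ccccc1Cl`) gives 1930 nM
Compound 2 (`O=C(Nc1ccccc1O)C1CCc2ccccc2N1C(=O)c1ccccc1Cl`) gives 36800 nM
Compound 3 (`O=C(Nc1ccccc1C(F)(F)F)C1CCc2ccccc2N1C(=O)c1ccc(Cl)cc1`) gives 551 nM

Compound 1 at 1930 nM stands in the middle of these three numbers. Compound 3 at 551 nM lies lower and compound 2 at 36800 nM lies higher, and both gaps go beyond the usual scatter.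

Compound 4 (`O=C(Nc1cc(C(F)(F)F)cc(C(F)(F)F)c1)C1CCc2ccccc2N1C(=O)c1cccc(Cl)c1`) has not yet been measured. It differs from compound 1 in one place (3-chlorophenyl in place of 2-chlorophenyl on a carbonyl carbon), with 3-chlorophenyl in place of 2-chlorophenyl on a carbonyl carbon. The two have the same atoms, joined differently. Within the data shown here, no measured pair shows this same change, so the data give no direct guide to its size. In this assay a small step towards a lower number is expected, one that stays within the scatter (a 1.3-fold lower number from compound 1 to compound 4 (0.11 log units; within the scatter)). For compound 4 the estimated value is 1500 nM with an expected range from 500 nM to 4500 nM in this test.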

Compound 4, concentration for 50% growth inhibition: 560 nM
Estimate against measurement, compound 4: 2.7-fold (0.43 log units) above; the range from low to high includes it.
By their numbers in this assay, from the lowest: compounds 3 and 4 (each within the scatter of the next); then compound 1; then compound 2.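

In this assay, among these compounds, the swap of 2-chlorophenyl for 3-chlorophenyl on the carbonyl carbon gives a 3.4-fold lower number from compound 1 to compound 4 (0.54 log units; beyond the scatter), a modest step but the first single change that can be read in this set. The two compounds have the same atoms, joined differently, so this position responds to where the chlorine sits and not only to whether one is present. Nothing at hand explains why the number falls with this move.

The compounds shown leave open how a plain phenyl with no chlorine, or a bromophenyl, would compare on the core of compound 1. They also leave open whether the same chlorine move gives a similar step when the bis(trifluoromethyl)phenyl on the amide nitrogen is replaced by another group.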